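Extending the Chain of Compound 2

This account rests on a few compounds, and the source may have more. Where it says the series, first, only, none or still open, it means among the compounds named here.

In a functional assay on SW480 cells (Homo sapiens) for antiproliferative activity, read by MTT assay, with a stated time of 48 h (on this read-out higher numbers stand for weaker inhibition and lower numbers for stronger inhibition), compound 2 (`CC(CCO)n1cnc2c(Cl)ncnc21`) reads > 50000 nM and this is a limit, not a number. Compound 3 (`CCCCC(CCO)n1cnc2c(N)ncnc21`) reads > 50000 nM in this assay and this too is a limit. Only compound 1 (`CC(CCO)n1cnc2c(Cl)nc(F)nc21`) gives a number, with 16800 nM as its reading. Among the measured compounds shown here, the record is thus dominated by the limit of > 50000 nM in this assay, at which 2 of the 3 values shown sit, and its sole measured step is an at least 2.9-fold higher number from compound 1 to compound 2 (0.47 log units; beyond the scatter) at an aromatic carbon. Compound 4 (`CCCCCC(CCO)n1cnc2c(Cl)ncnc21`) departs from compound 2 at a different place, with butyl in place of hydrogen on a saturated chain carbon, two bonds along the chain from an aromatic nitrogen as the change, which also reads methyl to pentyl. For the measured compounds named here, no measured step covers this place, so the step at the aromatic carbon serves only as a rough guide to size. Taking compound 1 at 16800 nM as the one measured number, a modest move toward stronger inhibition is expected. A result at the limit remains quite possible. The expected change is an at least 1.6-fold lower number from compound 2 to compound 4 (0.22 log units; that floor lies within the scatter) as estimated here. Compound 4 is estimated at 30000 nM with an expected range from 10000 nM to 70000 nM in this assay once measured.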

Compound 4, half-maximal inhibitory concentration: > 50000 nM
Compound 4 gave a limit, no number; the forecaster's own chance of this, stated with the estimate: 40%; middle value at least 1.6-fold (0.22 log units) away from the limit.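

In this assay compound 4 reads > 50000 nM, a limit and not a number. Compound 2 also stands at a limit, and the step between compound 2 and compound 4 cannot be read. Whether the longer chain changes inhibition at all remains open, with most of the record at the limit: the limit of > 50000 nM in this assay, at which 3 of the 4 values shown sit.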